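A few compounds are considered here, and "the series" means these few. Any claim that something is new, unique, unknown or untested is made for them only; others in the source may bear on it.

In an ADME assay on MT4 cells (Homo sapiens) for cytotoxicity, read by MTT assay, with a stated time of 4 days (on this read-out lower numbers stand for higher toxicity in this test and higher numbers for lower toxicity in this test), compound 3 `Cc1cc(C)cc(C(=O)c2cc(Br)ccc2OCCn2ccc(=O)[nH]c2=O)c1` gives only a limit, > 282000 nM, rather than a number. It is not alone in this. Compound 1 `O=C(c1ccccc1)c1cc(Br)ccc1OCCn1ccc(=O)[nH]c1=O` also gives only a limit, > 301000 nM. Compound 2 `O=C(c1cc(Cl)cc(Cl)c1)c1cc(Cl)ccc1OCCn1ccc(=O)[nH]c1=O`, which likewise bears a 3,5-dichlorophenyl on a carbonyl carbon, gives a limit too, > 284000 nM.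

Compound 4 `O=C(c1cc(Cl)cc(Cl)c1)c1cc(Br)ccc1OCCn1ccc(=O)[nH]c1=O` has 3,5-dichlorophenyl in place of the 3,5-dimethylphenyl of compound 3, on a carbonyl carbon: 3,5-dichlorophenyl in place of 3,5-dimethylphenyl on a carbonyl carbon.

Within the data shown here, the one measured step that bears on this change is a step that the two limits leave unreadable from compound 1 to compound 3, and it has no readable size. So no measured step points to a real shift in either direction. The limit of compound 2 at > 284000 nM gives no sign of toxicity with this group in place. The expected result is an at least 1.0-fold lower number from compound 3 to compound 4 (0.03 log units; that floor lies within the scatter), which means no change beyond the usual scatter, and this assay will most likely report another limit. For compound 4 the estimated value is 258000 nM, with an expected range from 120000 nM to 300000 nM.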

Compound 4, half-maximal cytotoxic concentration in the MT4 assay: > 258000 nM
Compound 4 was reported as a limit; the forecaster's own chance of this, stated with the estimate: 85%; the middle value lies on the limit itself.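

In the MT4 assay compound 4 gives > 258000 nM and this is only a limit. Compound 1, compound 2 and compound 3 also give only limits, so no step among these four compounds can be read. The compounds shown leave open at what concentration, if any, each of them would become toxic to these cells. In a physicochemical assay for solubility (on this read-out lower numbers stand for lower solubility and higher numbers for higher solubility), compound 3 gives 6600 nM and compound 4 gives 1500 nM in this test.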